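Halogen exchange on the anilino ring, second instance

The source may report more compounds than this note shows. Statements on the series, on what has been measured and on what is new or still open speak of the compounds shown alone.

Compound 1 `C=CC(=O)Nc1cccc(NC(=O)CSc2nc(Nc3ccccc3Cl)c3ccccc3n2)c1` gives 20700 nM in a functional assay on MGC-803 cells (Homo sapiens) for inhibition, read by MTT assay, with a stated time of 72 h; a lower number here means a stronger inhibitor, a higher number a weaker inhibitor. Compound 2 `C=CC(=O)Nc1cccc(NC(=O)CSc2nc(Nc3ccccc3Br)c3ccccc3n2)c1` carries bromo in place of chloro on an aromatic carbon and gives 12800 nM in this assay; the step is a 1.6-fold lower number from compound 1 to compound 2 (0.21 log units; within the scatter). Compound 3 `C=CC(=O)Nc1cccc(NC(=O)CSc2nc(Nc3ccc(Cl)cc3)c3ccccc3n2)c1` differs from compound 1 in 4-chlorophenyl in place of 2-chlorophenyl on a nitrogen on an aromatic ring. In this assay compound 3 gives 14300 nM; the steps are a 1.4-fold lower number from compound 1 to compound 3 (0.16 log units; within the scatter) and a 1.1-fold higher number from compound 2 to compound 3 (0.05 log units; within the scatter). Compound 4 `C=CC(=O)Nc1cccc(NC(=O)CSc2nc(Nc3ccc(Br)cc3)c3ccccc3n2)c1` is not yet measured and differs from compound 3 in bromo in place of chloro on an aromatic carbon. Going by the values given here, this is the same kind of change as the one leading to compound 2, but there the exchanged atom sits ortho to a large group, whereas here it sits para to a large group. Expected for this assay is a step of a 1.4-fold lower number from compound 3 to compound 4 (0.16 log units; within the scatter), resting on the earlier step of a 1.6-fold lower number from compound 1 to compound 2 (0.21 log units; within the scatter) and staying within the scatter. Compound 4 is accordingly estimated at 10000 nM, with a range from 4500 nM to 22000 nM.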

Compound 4, half-maximal inhibitory concentration: 11500 nM
The estimate for compound 4 lay 1.2-fold (0.06 log units) below the measured number, and the stated range covers the measured number.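

In this assay, bromo in place of chloro on the 4-chlorophenyl group gives a 1.2-fold lower number from compound 3 to compound 4 (0.09 log units; within the scatter), and the other two new steps, a 1.1-fold lower number from compound 2 to compound 4 (0.05 log units; within the scatter) and a 1.8-fold lower number from compound 1 to compound 4 (0.26 log units; within the scatter), also stay within the scatter. Carried from the core of compound 1 to the core of compound 3, the change shows no difference that can be told apart: the same change on two cores in this assay, a 1.6-fold lower number (0.21 log units; within the scatter) from compound 1 to compound 2 and a 1.2-fold lower number (0.09 log units; within the scatter) from compound 3 to compound 4, 1.3-fold (0.11 log units) apart, within the scatter of two such steps With every step within the scatter, this does not show that bromo lowers the number on either core, nor that the change would behave alike on any core beyond these four compounds.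

Open, going by these compounds, is whether fluoro or iodo in the same place would read differently from chloro and bromo. Also open, on these data alone, is whether a methoxy group, an amine or a carboxylic acid there would move the number beyond the scatter.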